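A few compounds are considered here, and "the series" means these few. Any claim that something is new, unique, unknown or untested is made for them only; others in the source may bear on it.

Compound 1 `Cc1ccc(/C=C/C(=O)NNC(=O)c2ccc3c(c2)OCCO3)cc1` stands highest of the three numbers in an ADME assay on cells (Macrophage) for cytotoxicity, read by MTT assay, with a stated time of 24 h (a lower number here means that less compound is tolerated, a higher number that more compound is tolerated), where compound 1 gives 332000 nM. Compound 2 `COc1ccccc1/C=C/C(=O)NNC(=O)c1ccc2c(c1)OCCO2` gives 312000 nM and compound 3 `Cc1ccccc1/C=C/C(=O)NNC(=O)c1ccc2c(c1)OCCO2` gives 268000 nM; the steps of a 1.1-fold lower number from compound 1 to compound 2 (0.03 log units; within the scatter) and a 1.2-fold lower number from compound 1 to compound 3 (0.09 log units; within the scatter) stay within the scatter, as does a 1.2-fold lower number from compound 2 to compound 3 (0.07 log units; within the scatter). Compound 4 `COc1cccc(/C=C/C(=O)NNC(=O)c2ccc3c(c2)OCCO3)c1` has not yet been measured in this assay. Its change from compound 1 is: 3-methoxyphenyl in place of 4-methylphenyl on a double-bonded chain carbon bound to a double-bonded chain carbon. The measured steps that bear on it, a 1.1-fold lower number from compound 1 to compound 2 (0.03 log units; within the scatter) and a 1.2-fold lower number from compound 1 to compound 3 (0.09 log units; within the scatter), are both small, so no step beyond the scatter is expected in this assay. Compound 4 is estimated to give 310000 nM, with a range of 200000 nM to 480000 nM, which means an expected step of a 1.1-fold lower number from compound 1 to compound 4 (0.03 log units; within the scatter).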

Compound 4, half-maximal cytotoxic concentration: 398000 nM
Compound 4: middle estimate off by 1.3-fold (0.11 log units), on the low side, within the range that was stated.
By their numbers in this assay, from the lowest: compounds 3, 2, 1 and 4 (each within the scatter of the next).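

In this assay the 3-methoxyphenyl group gives a 1.2-fold higher number from compound 1 to compound 4 (0.08 log units; within the scatter) and a 1.3-fold higher number from compound 2 to compound 4 (0.11 log units; within the scatter) and also a 1.5-fold higher number from compound 3 to compound 4 (0.17 log units; within the scatter) so it cannot be told apart from 4-methylphenyl, 2-methoxyphenyl or 2-methylphenyl. Across these four substituted phenyl groups, this place on a double-bonded chain carbon has shown no step beyond the scatter, even with the added oxygen of the methoxy group. No measured evidence here explains these numbers.

Every compound shown carries a phenyl group with methyl or methoxy at this place. Going by these compounds, whether an amine, a carboxylic acid or a longer chain there would shift the number remains open.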